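The source may hold more compounds than are shown below. What is called first, only, known or untested is meant among the compounds shown, and "the series" means these compounds.

Compound 1 `O=C(Nc1cccc(-n2cc(-c3ccncc3)c(-c3cc(O)cc(Cl)c3)n2)c1)Nc1ccc(Cl)c(Cl)c1`: -56.5%
Compound 2 `COc1cc(Cl)cc(-c2nn(-c3cccc(NC(=O)Nc4ccc(Cl)c(C(F)(F)F)c4)c3)cc2-c2ccncc2)c1`: -48.3%

Both numbers come from a functional assay on U-251 cells (Homo sapiens) for inhibition, read by sulforhodamine B assay, with a stated time of 48 h, tested at 10 uM; a lower number here means a stronger effect, a higher number a weaker effect of the compound at the concentration tested. Compound 2 and compound 1 lie within the usual scatter of each other, so neither can be called the stronger of the two. Compound 3 `COc1cc(Cl)cc(-c2nn(-c3cccc(NC(=O)Nc4ccc(Cl)c(Cl)c4)c3)cc2-c2ccncc2)c1` has not yet been measured. It differs from compound 2 in a single place: chloro in place of trifluoromethyl on an aromatic carbon. Within the data shown here, no measured pair shows this change on its own, so its effect here is unknown. The expected step from compound 2 to compound 3 is therefore small, a number 3.7 percentage points lower from compound 2 to compound 3 (within the scatter), none beyond the scatter. Compound 3 is estimated to give about -52% in this assay, most likely between -75% and -28%.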

Compound 3, a percentage reported as activity, at one concentration (the size of the read-out at that concentration, not a potency): 3.01%
Beside the measured number, compound 3's estimate is 55 percentage points below it; measured number above the stated range.
By their numbers in this assay, from the lowest: compounds 1 and 2 (each within the scatter of the next); then compound 3.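

Chloro in place of trifluoromethyl, ortho to a chloro group, gives a number 51.3 percentage points higher from compound 2 to compound 3 (beyond the scatter) in this assay and shows that this one place can decide the read-out. Methyl in place of hydrogen on the oxygen gives a number 59.5 percentage points higher from compound 1 to compound 3 (beyond the scatter) as a second large step, and only compound 3 carries both the chloro and that methyl. Nothing measured here explains either step.

Open, going by these compounds, is what bromo or a nitrile would do at this position. Also open, on these data alone, is how trifluoromethyl behaves with hydrogen on that oxygen.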